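Methyl for methoxy on two related fused cores

The source may hold more compounds than are shown below. What is called first, only, known or untested is meant among the compounds shown, and "the series" means these compounds.

Compound 1 `COc1ccc2[nH]c3c4cn[nH]c4c4c(c3c2c1)C(=O)NC4=O` and compound 2 `Cc1ccc2[nH]c3c4cn[nH]c4c4c(c3c2c1)C(=O)NC4=O` share one core; compound 3 `COc1ccc2[nH]c3c(c4c(c5ccnn53)C(=O)NC4=O)c2c1` and compound 4 `Cc1ccc2[nH]c3c(c4c(c5ccnn53)C(=O)NC4=O)c2c1` share another. Compound 3 has the same atoms as compound 1, joined differently; the difference between the two cores is not broken down here.

In a functional assay on LoVo cells (Homo sapiens) for cytotoxicity, read by MTT assay, with a stated time of 72 h (on this read-out lower numbers stand for stronger inhibition and higher numbers for weaker inhibition), compound 1 gives 42000 nM and compound 2 gives 5000 nM. The step of an 8.4-fold lower number from compound 1 to compound 2 (0.92 log units; beyond the scatter) corresponds to methyl in place of methoxy on an aromatic carbon. In this assay compound 3 gives 34000 nM; compound 3 and compound 1 lie within the scatter of each other, while compound 2 lies beyond the scatter from compound 3, with the lower number.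

Compound 4 has not been measured in this assay. Among the compounds with values here, the change from compound 3 to compound 4 is methyl in place of methoxy on an aromatic carbon, the same change as from compound 1 to compound 2, with the surroundings of the place described in the same words; it is the only repeated change in the set, once measured and once pending.

Within the data shown here, a step in the same direction, and of similar size, is expected from compound 3 to compound 4, a 5.7-fold lower number from compound 3 to compound 4 (0.75 log units; beyond the scatter), somewhat smaller than the measured case because the single instance an 8.4-fold lower number from compound 1 to compound 2 (0.92 log units; beyond the scatter) sits on a different core and a single pair gives no measure of how well the step carries over.

In this assay compound 4 is expected to give about 6000 nM, with a likely range from 2500 nM to 15000 nM.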

Compound 4, half-maximal inhibitory concentration: 4000 nM
Compound 4: middle estimate off by 1.5-fold (0.18 log units), on the high side, within the range that was stated.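

In this assay, methyl in place of methoxy on an aromatic carbon gives an 8.5-fold lower number from compound 3 to compound 4 (0.93 log units; beyond the scatter) and, set beside the earlier case, the step keeps its direction and its size across the two cores: the same change on two cores in this assay, an 8.4-fold lower number (0.92 log units; beyond the scatter) from compound 1 to compound 2 and an 8.5-fold lower number (0.93 log units; beyond the scatter) from compound 3 to compound 4, 1.0-fold (0.01 log units) apart, within the scatter of two such steps. For these two cores, then, the step measured on the core of compound 1 also holds on the core of compound 3, and knowing the core made no visible difference to this particular change. The finding rests on two pairs in a single cell assay at one stated time, so it does not show that the step would carry to a further core, to another read-out or to another group at this place, and it gives no reason why the methyl compounds have the lower numbers.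

The compounds shown leave open whether the step is special to methoxy and methyl, a question that an ethyl group, a chlorine atom, a hydroxyl group or an amine on the same aromatic carbon would address. Also open, from the compounds shown here alone, is whether the agreement between the two cores survives a change elsewhere, such as a longer chain in place of the amide hydrogen.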